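This account rests on a few compounds, and the source may have more. Where it says the series, first, only, none or still open, it means among the compounds named here.

In a functional assay on HCT-116 cells (Homo sapiens) for cytotoxicity, read by MTT assay, with a stated time of 48 h, in the presence of a further agent that is not named here (on this read-out higher numbers stand for an effect only at larger amounts of compound and lower numbers for an effect already at smaller amounts), compound 1 `Cc1nn(C)c2nc(NNC(=O)Nc3cc(Cl)nc(Cl)c3)cc(C3CCCCC3)c12` gives 38000 nM, compound 2 `COc1ccc(-c2cc(NNC(=O)Nc3cc(Br)nc(Br)c3)nc3c2cnn3C)cc1` gives 45200 nM and compound 3 `COc1cc(NC(=O)NNc2cc(-c3ccc(F)cc3)c3cnn(C)c3n2)cc(Cl)n1` gives 75300 nM. These three values lie within the usual scatter of one another, so compound 2 cannot be separated from either of the other two. Compound 4 `CCCOc1cc(NC(=O)NNc2cc(-c3ccc(OC)cc3)c3cnn(C)c3n2)cc(Cl)n1` has 2-chloro-6-propoxypyridin-4-yl in place of 2,6-dibromopyridin-4-yl on an amide-type nitrogen. For the measured compounds named here, no measured pair of compounds differs in one place only, so the only guide is the close grouping of the three values, and no step beyond the scatter is expected in this assay. The expected result is a small step of a 1.2-fold higher number from compound 2 to compound 4 (0.09 log units; within the scatter). For compound 4 the estimated value is 55000 nM, with an expected range of 25000 nM to 120000 nM.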

Compound 4, half-maximal effective concentration: 33300 nM
Compound 4: middle estimate off by 1.7-fold (0.22 log units), on the high side, and the stated range covers the measured number.
By their numbers in this assay, from the lowest: compounds 4, 1, 2 and 3 (each within the scatter of the next, the first and the last beyond it).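

In this assay, for the compounds shown here, the first comparison that changes one place only gives a 1.4-fold lower number from compound 2 to compound 4 (0.13 log units; within the scatter), so this change on the amide-type nitrogen cannot be told apart from no change. The position therefore accepts 2-chloro-6-propoxypyridin-4-yl, with more heavy atoms and an added oxygen, in place of 2,6-dibromopyridin-4-yl without a step beyond the scatter. Nothing measured here bears on why this is so.

From the compounds shown here alone, because both substituents on the pyridine differ at once, the effect of each alone stays open. Going by these compounds, whether an amine, a carboxylic acid or a chain longer than propoxy on this pyridine would give a clear step also stays open.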